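The source may hold more compounds than are shown below. What is called first, only, known or untested is meant among the compounds shown, and "the series" means these compounds.

Compound 1, `Cc1ccc(-[n+]2noc([O-])c2CN2CCCCC2)cc1`, was tested in an ADME assay on HEL cells (Homo sapiens) for cytotoxicity (a lower number here means that less compound is tolerated, a higher number that more compound is tolerated), where compound 1 gives 100 ug/mL. Compound 2, `CN1CCN(Cc2c([O-])on[n+]2-c2ccc(Cc3ccc(-[n+]4noc([O-])c4CN4CCN(C)C(c5ccccc5)C4)cc3)cc2)CC1c1ccccc1`, is a much larger molecule built from two copies of a similar core, and in this assay compound 2 gives 100 ug/mL. Compound 1 stands level with compound 2 at the digits shown, with no change beyond the usual scatter of this kind of measurement. Compound 3, `Cc1ccc(-[n+]2noc([O-])c2CN2CCN(C)CC2)cc1`, differs from compound 1 in one place: 4-methylpiperazin-1-yl in place of piperidin-1-yl on a saturated chain carbon bound to an aromatic carbon. Among the compounds with values here, no measured pair shows this exact change, so the size of the step has to be judged from the two values at hand, which agree with each other despite very different groups on the saturated chain carbon. The step is therefore expected to be none beyond the scatter, no change at the digits printed from compound 1 to compound 3 (within the scatter). Compound 3 is expected to give 100 ug/mL, with a range from 50 ug/mL to 200 ug/mL.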

Compound 3, minimum cytotoxic concentration: 100 ug/mL
Estimate against measurement, compound 3: no gap at the digits printed; measured number inside the range.
By their numbers in this assay, from the lowest: compounds 1, 2 and 3 (each within the scatter of the next).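

Putting 4-methylpiperazin-1-yl in place of piperidin-1-yl on a saturated chain carbon bound to an aromatic carbon leaves the reading in this assay unmoved (no change at the digits printed from compound 1 to compound 3 (within the scatter)). Within the data shown here, this is the first direct comparison at this place in which only one group differs, so the second hetero atom in the six-membered ring, together with the extra heavy atom, can be seen to make no difference beyond the scatter on the core of compound 1. Nothing measured here bears on why the two groups read alike.

As far as these compounds go, what a morpholin-4-yl ring or an open-chain diethylamino group would do at this place remains open. From the compounds shown here alone, it also remains open whether the same swap would read alike on a different core, or in any other test.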